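Acetyl Replaces Isobutyl on the Piperidine Nitrogen

The source may report more compounds than this note shows. Statements on the series, on what has been measured and on what is new or still open speak of the compounds shown alone.

Compound 1 `Cc1ccc2nc([C@H](CC3CCNCC3)N3C(=O)CN(c4ccc(Oc5ccccc5)cc4)C3=O)n(C)c2c1`: 64000 nM
Compound 2 `Cc1ccc2nc([C@H](CC3CCN(CC(C)C)CC3)N3C(=O)CN(c4ccc(Oc5ccccc5)cc4)C3=O)n(C)c2c1`: 16400 nM

In an assay on isolated protein for antagonist activity at Bile acid receptor (Homo sapiens), read by TR-FRET and LanthaScreen (a lower number here means a stronger inhibitor, a higher number a weaker inhibitor), compound 2 gives the lowest number of the two measured compounds; the nearest is compound 1, whose value stands higher by a 3.9-fold lower number from compound 1 to compound 2 (0.59 log units; beyond the scatter). Compound 3 `CC(=O)N1CCC(C[C@@H](c2nc3ccc(C)cc3n2C)N2C(=O)CN(c3ccc(Oc4ccccc4)cc3)C2=O)CC1` differs from compound 2 by acetyl in place of isobutyl on an amine nitrogen in a ring. For the measured compounds named here, only that one step, which added a substituent at the same nitrogen, bears on the change; it was modest. Because of a 3.9-fold lower number from compound 1 to compound 2 (0.59 log units; beyond the scatter), a group on that nitrogen seems to matter, but acetyl is unlike isobutyl, so the direction is uncertain. Compound 3 is expected to give 30000 nM (range 8000 nM to 100000 nM), a change of a 1.8-fold higher number from compound 2 to compound 3 (0.26 log units; within the scatter) from compound 2.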

Compound 3, half-maximal inhibitory concentration: 1300 nM
Compound 3: middle estimate off by 23-fold (1.36 log units), on the high side; measured number outside the range, below it.
By their numbers in this assay, from the lowest: compound 3; then compound 2; then compound 1.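

In this assay the group on the amine nitrogen in the ring matters by its kind and not merely by its presence: acetyl in place of isobutyl gives a 13-fold lower number from compound 2 to compound 3 (1.10 log units; beyond the scatter). Acetyl in place of hydrogen gives a 49-fold lower number from compound 1 to compound 3 (1.69 log units; beyond the scatter), a larger step than isobutyl gave on the same nitrogen. Nothing available explains why acetyl gives the lowest number. From the compounds shown here alone, it stays open whether the carbonyl alone accounts for the step or the whole acetyl group is needed. A sulfonamide, a urea or a longer acyl chain such as propionyl on that nitrogen would help to separate these readings.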